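Cyclopropylmethoxy to propoxy at the limit of the assay

The source may hold more compounds than are shown below. What is called first, only, known or untested is meant among the compounds shown, and "the series" means these compounds.

In a functional assay on PC-12 cells (Rattus norvegicus) for inhibition, read by sulforhodamine B assay (on this read-out higher numbers stand for weaker inhibition and lower numbers for stronger inhibition), compound 1 (`Cc1c(C)c2c(c(C)c1O)CCC(C)(COc1ccc(/C=C3/SC(=O)NC3=O)cc1)O2`) gives 5000 nM. Compound 2 (`O=C1NC(=O)C(Cc2ccc(OCC3CCCCO3)cc2)S1`) reads > 100000 nM, which is a limit of the assay. Compound 3 (`O=C1NC(=O)C(Cc2ccc(OCC3CC3)cc2)S1`) reads > 100000 nM, again a limit and not a number. Compound 3 therefore stands at the limit of > 100000 nM in this assay, at which 2 of the 3 values shown sit. Compound 4 (`CCCOc1ccc(CC2SC(=O)NC2=O)cc1`) differs from it as follows: ethyl in place of cyclopropyl on a saturated chain carbon bound to an oxygen on an aromatic ring. Put in words, ethyl replaces cyclopropyl, turning cyclopropylmethoxy into propoxy. For the measured compounds named here, the one measured step at this place is a step that the two limits leave unreadable from compound 2 to compound 3, so it offers no size to carry over. In this assay the expected result is a number no higher from compound 3 to compound 4 (the limit leaves the size open), with nothing beyond the scatter and no direction foreseen. Compound 4 is estimated at 100000 nM, with an expected range of 30000 nM to 300000 nM.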

Compound 4, half-maximal inhibitory concentration: 45000 nM
Compound 4: the middle estimate sits 2.2-fold (0.35 log units) above what was measured, within the range that was stated.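

In this assay, for the compounds shown here, the ether side chain on the shared core had so far given only limits, not numbers: the limit of > 100000 nM in this assay, at which 2 of the 4 values shown sit. Ethyl in place of cyclopropyl gives an at least 2.2-fold lower number from compound 3 to compound 4 (0.34 log units; beyond the scatter), and ethyl in place of oxan-2-yl gives an at least 2.2-fold lower number from compound 2 to compound 4 (0.34 log units; beyond the scatter). Propoxy is thus the first of these side chains to give a readable number, and both steps lie beyond the scatter.

Going by these compounds, the step between the two limits cannot be read, and the true size of both new steps stays open. On these data alone, whether a longer chain such as butoxy, or a carboxylic acid at the chain end, would lower the number further also remains open.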